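Hydroxyl for Methyl on the Nitrogen-Bound Aryl

The source may hold more compounds than are shown below. What is called first, only, known or untested is meant among the compounds shown, and "the series" means these compounds.

For the measured compounds named here, compound 3 `Cc1cccc(N2N=C(C(C)(C)C)CC2c2ccc(O)cc2)c1` is one of three compounds measured in an assay on isolated protein for inhibition of protein kinase C zeta type (Homo sapiens), with a stated time of 4 min, tested at 62.5 uM (a higher number here means more inhibition at the concentration tested (going by the name of the read-out), a lower number less inhibition), where compound 3 gives 91.7%. Compound 1 `CC(C)(C)C1=NN(c2ccc(Br)cc2)C(c2ccc(O)cc2)C1` gives 93.2% and compound 2 `CC(C)(C)C1=NN(c2cccc(C(F)(F)F)c2)C(c2ccc(O)cc2)C1` gives 96.1%. Compound 3 holds the lowest of the three numbers, but the two steps that lead to it, a number 1.5 percentage points lower from compound 1 to compound 3 (within the scatter) and a number 4.4 percentage points lower from compound 2 to compound 3 (within the scatter), both lie within the scatter, so these data do not separate the three compounds from one another.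

Compound 4 `CC(C)(C)C1=NN(c2ccc(O)cc2)C(c2ccc(O)cc2)C1` differs from compound 3 in one place: 4-hydroxyphenyl in place of 3-methylphenyl on an amine nitrogen in a ring. Going by the values given here, neither measured step bears directly on this change, as neither brings in a hydroxyl; the only guide is that compound 1 with its 4-bromophenyl and compound 2 with its trifluoromethyl sit within the scatter of compound 3. Compound 4 is therefore expected to stay near compound 3, with an expected step of a number 0.3 percentage points higher from compound 3 to compound 4 (within the scatter) that does not go beyond the scatter. The estimate for compound 4 is 92%, with a range from 82% to 98%.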

Compound 4, a percentage reported as inhibition, at one concentration (the size of the read-out at that concentration, not a potency): 40.9%
Compound 4: the middle estimate sits 51.1 percentage points above what was measured; measured number below the stated range.
By their numbers in this assay, from the lowest: compound 4; then compounds 3, 1 and 2 (each within the scatter of the next).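

The position on an amine nitrogen in a ring is not indifferent to its aryl group in this assay, although the three earlier groups gave no sign of this. The change to 4-hydroxyphenyl gives a number 50.8 percentage points lower from compound 3 to compound 4 (beyond the scatter), and hydroxy in place of bromo gives a number 52.3 percentage points lower from compound 1 to compound 4 (beyond the scatter), so a single change on this ring can take away much of the inhibition seen at the tested concentration. The 3-methylphenyl that leaves counts no hydrogen-bond donor and the 4-hydroxyphenyl that enters counts one, but no measurement here gives a reason for the drop.

The compounds shown leave open whether the loss belongs to the hydroxy itself or to its place on the ring: 4-hydroxyphenyl is the only hydroxy-bearing group here at this position. They also leave open how a methoxy or an amine in that same place would read in this assay.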